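A few compounds are considered here, and "the series" means these few. Any claim that something is new, unique, unknown or untested is made for them only; others in the source may bear on it.

Measured so far in a physicochemical assay for solubility, in phosphate buffer, at pH 7.4; on this read-out higher numbers stand for higher solubility and lower numbers for lower solubility:
- compound 1 `C[C@@H]1CN(C(=O)OC(C)(C)C)CCN1c1ncc(OCC2CCN(S(C)(=O)=O)CC2)cn1` gives < 5000 nM as a limit
- compound 2 `C[C@@H]1CN(C(=O)OC(C)(C)C)CCN1c1ncc(OCc2ccc(C#N)cc2)cn1` gives < 5000 nM as a limit
- compound 3 `C[C@@H]1CN(C(=O)OC(C)(C)C)CCN1c1ncc(OCc2ccc(S(C)(=O)=O)cc2F)cn1` gives < 5000 nM as a limit

Compound 3 stands at < 5000 nM and this is a limit, not a number. Among the measured compounds shown here, the series as a whole shows the limit of < 5000 nM in this assay, at which 3 of the 3 values shown sit, and no compound has a readable value yet.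

Compound 4 `Cc1cnccc1COc1cnc(N2CCN(C(=O)OC(C)(C)C)C[C@H]2C)nc1` is not yet measured. It carries 3-methylpyridin-4-yl in place of 2-fluoro-4-(methylsulfonyl)phenyl on a saturated chain carbon bound to an oxygen on an aromatic ring, as counted here: 3-methylpyridin-4-yl in place of 2-fluoro-4-(methylsulfonyl)phenyl on a saturated chain carbon bound to an oxygen on an aromatic ring.

Three measured steps change the group at this same place: a step that the two limits leave unreadable from compound 1 to compound 2 and a step that the two limits leave unreadable from compound 1 to compound 3 and a step that the two limits leave unreadable from compound 2 to compound 3 together give no size to carry over. None of them involves 3-methylpyridin-4-yl. No direction can be read from them, so no step beyond the scatter is expected in this assay for now. The estimated step is a step that the limit leaves unreadable from compound 3 to compound 4 and a report at the same limit is likely. Compound 4 is estimated at 4000 nM with an expected range of 1000 nM to 20000 nM in this read-out.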

Compound 4, solubility: 45000 nM
Estimate against measurement, compound 4: 11-fold (1.05 log units) below; the whole stated range lies below it.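

Compound 4, with 3-methylpyridin-4-yl on the saturated chain carbon bound to an oxygen on an aromatic ring, is the first compound in the series with a readable value in this assay, so a change at this position can give a number clear of the limit: the limit of < 5000 nM in this assay, at which 3 of the 4 values shown sit.

The change reads as an at least 9.0-fold higher number from compound 3 to compound 4 (0.95 log units; beyond the scatter), as an at least 9.0-fold higher number from compound 2 to compound 4 (0.95 log units; beyond the scatter) and as an at least 9.0-fold higher number from compound 1 to compound 4 (0.95 log units; beyond the scatter). Each of these steps starts from a limit, and the steps among compound 1, compound 2 and compound 3 cannot be read, so the three groups replaced cannot be ranked.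

The compounds shown do not separate the ring nitrogen from the methyl, which pyridin-4-yl without the methyl or a phenyl carrying only the methyl would address. On these data alone, it also stays open whether an aliphatic amine such as morpholine at this place would give a similar step.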